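Indole for trifluoromethylphenyl on the hydrazone carbon

The compounds below may be only part of what the source reports. "The series", "measured", "known", "first", "only" and "open" are said of these compounds alone.

Measured in a functional assay on MDA-MB-231 cells (Homo sapiens) for cytotoxicity, read by MTT assay, with a stated time of 72 h; on this read-out lower numbers stand for stronger inhibition and higher numbers for weaker inhibition:
compound 1 `COc1ccc(/C=N/NC(=O)Nc2ccc(Oc3ccnc4cc(OCCCN5CCCCC5)c(OC)cc34)c(F)c2)cc1`, 840 nM
compound 2 `COc1cc2c(Oc3ccc(NC(=O)N/N=C/c4ccc(C(F)(F)F)cc4)cc3F)ccnc2cc1OCCCN1CCCCC1`, 1100 nM
compound 3 `COc1cc2c(Oc3ccc(NC(=O)N/N=C/c4ccc(N(C)C)cc4)cc3F)ccnc2cc1OCCCN1CCCCC1`, 1400 nM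

Compound 2 stands second highest of the three numbers: a 1.3-fold higher number from compound 2 to compound 3 (0.10 log units; within the scatter) and, in the other direction, a 1.3-fold higher number from compound 1 to compound 2 (0.12 log units; within the scatter). Compound 4 `COc1cc2c(Oc3ccc(NC(=O)N/N=C/c4cc5ccccc5[nH]4)cc3F)ccnc2cc1OCCCN1CCCCC1` differs from compound 2 by 1H-indol-2-yl in place of 4-(trifluoromethyl)phenyl on a carbon with a double bond to nitrogen. The measured steps all swap one substituent on an aromatic carbon: a 1.3-fold higher number from compound 1 to compound 2 (0.12 log units; within the scatter), a 1.7-fold higher number from compound 1 to compound 3 (0.22 log units; within the scatter), a 1.3-fold higher number from compound 2 to compound 3 (0.10 log units; within the scatter). None exchanges the whole ring, so they only show that this part of the molecule has tolerated change so far. Compound 4 is therefore expected to give about 1000 nM in this assay, within 400 nM to 3000 nM, a step of a 1.1-fold lower number from compound 2 to compound 4 (0.04 log units; within the scatter) that is not expected to exceed the scatter.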

Compound 4, half-maximal inhibitory concentration: 980 nM
Compound 4: the middle estimate sits 1.0-fold (0.01 log units) above what was measured, within the range that was stated.
By their numbers in this assay, from the lowest: compounds 1, 4, 2 and 3 (each within the scatter of the next).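

Within this assay the whole ring on the hydrazone carbon can be exchanged without leaving the scatter, with a 1.1-fold lower number from compound 2 to compound 4 (0.05 log units; within the scatter) and a 1.4-fold lower number from compound 3 to compound 4 (0.15 log units; within the scatter) and a 1.2-fold higher number from compound 1 to compound 4 (0.07 log units; within the scatter) as the steps. The substituent swaps did not show this: the position accepts a 1H-indol-2-yl group, with its hydrogen-bond donor, as well as the substituted phenyl rings. The compounds shown leave open whether an amine or a carboxylic acid on the indole, or a longer chain at this carbon, would give a step beyond the scatter. No evidence is available that explains these results.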